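The source may hold more compounds than are shown below. What is called first, only, known or untested is meant among the compounds shown, and "the series" means these compounds.

Going by the values given here, compound 1 `COc1ncc(-c2ccc3ncnc(Nc4ccc(OCCO)c(F)c4)c3c2)cc1NS(=O)(=O)c1ccc(F)cc1F` is one of three compounds measured in a functional assay on HCT-116 cells (Homo sapiens) for antiproliferative activity, read by sulforhodamine B assay, with a stated time of 72 h (a higher number here means a weaker inhibitor, a lower number a stronger inhibitor), where compound 1 gives 9160 nM. That is the highest of the three numbers: compound 2 `COc1ncc(-c2ccc3ncnc(Nc4cnn(CCCO)c4)c3c2)cc1NS(C)(=O)=O` gives 1420 nM in this assay, and compound 3 `COC(=O)CCn1cc(Nc2ncnc3ccc(-c4cnc(OC)c(NS(C)(=O)=O)c4)cc23)cn1` gives 970 nM, so both sit well beyond the scatter from compound 1 and mark it as the weakest inhibitor of the group. Compounds 2 and 3 differ from each other in one place only, and that step is a 1.5-fold lower number from compound 2 to compound 3 (0.17 log units; within the scatter).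

Compound 4 `COc1ncc(-c2ccc3ncnc(Nc4ccc(OCCCO)nc4)c3c2)cc1NS(=O)(=O)c1ccc(F)cc1F` has not yet been measured. It differs from compound 1 in one place: 6-(3-hydroxypropoxy)pyridin-3-yl in place of 3-fluoro-4-(2-hydroxyethoxy)phenyl on a nitrogen on an aromatic ring. Among the compounds with values here, no measured pair changes this part of the molecule, and compounds 2 and 3 differ from compound 1 in more than one place, so their numbers offer only loose guidance. Within the data shown here, the one measured step, a lengthening and capping of a hydroxyl chain, stayed within the scatter, which gives no sign that a chain or ring swap of this kind shifts the number greatly. The expectation is therefore a step of a 1.5-fold lower number from compound 1 to compound 4 (0.18 log units; within the scatter), with wide uncertainty. Compound 4 is expected to give about 6000 nM in this assay, in a range from 1500 nM to 25000 nM.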

Compound 4, half-maximal inhibitory concentration: 3680 nM
For compound 4 the middle estimate is 1.6-fold (0.21 log units) above the measured one, within the range that was stated.
By their numbers in this assay, from the lowest: compounds 3 and 2 (each within the scatter of the next); then compound 4; then compound 1.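

Going by these compounds alone, the step of a 2.5-fold lower number from compound 1 to compound 4 (0.40 log units; beyond the scatter) is the first measured change to the group on a nitrogen on an aromatic ring, and it shows that in this assay this group can move the number beyond the scatter, although only modestly. Within the data shown here, the only earlier step, a 1.5-fold lower number from compound 2 to compound 3 (0.17 log units; within the scatter), changed a different part of the molecule and stayed within the scatter. The new step is a bundle of changes, since the ring of carbon only becomes a ring with a hetero atom, the fluorine is gone and the hydroxyl chain changes from 2-hydroxyethoxy to 3-hydroxypropoxy, and no measurement here explains why the number falls.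

The compounds shown leave open which of these changes carries the step, a question that 6-(2-hydroxyethoxy)pyridin-3-yl or 3-fluoro-4-(3-hydroxypropoxy)phenyl on the same core could help settle. They also leave open how a dimethylamino group or a carboxylic acid in place of the hydroxyl of the 3-hydroxypropoxy chain would affect the number.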